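The source may report more compounds than this note shows. Statements on the series, on what has been measured and on what is new or still open speak of the compounds shown alone.

Compound 1 `O=C(Nc1ccc(C(F)(F)F)cc1)Nc1cc2ncncc2cc1OCc1cccc(F)c1` holds the highest of the two numbers recorded in a functional assay on GBM3 cells (Homo sapiens) for antiproliferative activity, read by WST assay, with a stated time of 72 h; on this read-out lower numbers stand for stronger inhibition and higher numbers for weaker inhibition: compound 1 gives 6300 nM. Going by the values given here, its only measured neighbour, compound 2 `O=C(Nc1ccc(Cl)c(Cl)c1)Nc1cc2ncncc2cc1OCc1cccc(F)c1`, gives 2000 nM in this assay, and a 3.2-fold lower number from compound 1 to compound 2 (0.50 log units; beyond the scatter); that step changes the aryl group on the amide-type nitrogen and leaves the benzyloxy side untouched. Compound 3 `O=C(Nc1ccc(C(F)(F)F)cc1)Nc1cc2ncncc2cc1OCc1ccccc1` differs from compound 1 in another place: hydrogen in place of fluoro on an aromatic carbon. Among the compounds with values here, no measured step reaches this part of the molecule, so the data give no direct guide, and the loss of the fluoro from the 3-fluorobenzyl group is expected to move the number by no more than the usual scatter, if at all. The estimate for compound 3 is therefore 7500 nM, with a range of 3000 nM to 18000 nM, which is expected to amount to a 1.2-fold higher number from compound 1 to compound 3 (0.08 log units; within the scatter).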

Compound 3, half-maximal inhibitory concentration: 3700 nM
Beside the measured number, compound 3's estimate is 2.0-fold (0.31 log units) above it; low and high end bracket the measured number.
By their numbers in this assay, from the lowest: compounds 2, 3 and 1 (each within the scatter of the next, the first and the last beyond it).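

Going by these compounds alone, the first measured step on the benzyloxy side, hydrogen in place of fluoro on an aromatic carbon, gives a 1.7-fold lower number from compound 1 to compound 3 (0.23 log units; within the scatter) and so stays within the usual scatter of this assay. With the 4-(trifluoromethyl)phenyl group held constant, the 3-fluorobenzyl and benzyl groups therefore cannot be told apart on this read-out, which shows that this fluoro is not required for the activity seen here. No measurement is available that could explain this result.

Going by these compounds, whether a larger or differently charged substituent on this ring, such as a methoxy group, an amine or a carboxylic acid, would give a step beyond the scatter remains open. On these data alone, it is also open whether the fluoro counts for as little when the 3,4-dichlorophenyl group of compound 2 is present.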